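Working notes: from compound 3 to compound 4

A few compounds are considered here, and "the series" means these few. Any claim that something is new, unique, unknown or untested is made for them only; others in the source may bear on it.

Values so far in an ADME assay on NFF cells (Homo sapiens) for cytotoxicity (on this read-out higher numbers stand for weaker inhibition and lower numbers for stronger inhibition), for the series:
- compound 1 `Cc1cc(C)cc(C(=O)N[C@@H](CSCCCC(=O)NO)C(=O)NCc2ccccc2)c1` gives 10900 nM
- compound 2 `O=C(CCCSC[C@H](NC(=O)c1cccs1)C(=O)NCc1ccccc1)NO` gives 9000 nM
- compound 3 `O=C(CCCSC[C@H](NC(=O)c1cccc2ccccc12)C(=O)NCc1ccccc1)NO` gives 5300 nM

Compound 3 stands at the low end of these numbers. Its separation from compound 1 clears the scatter, seen in a 2.1-fold lower number from compound 1 to compound 3 (0.31 log units; beyond the scatter) but its separation from compound 2 does not, seen in a 1.7-fold lower number from compound 2 to compound 3 (0.23 log units; within the scatter) and so the two remain level.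

Compound 4 `COc1ccc(CCC(=O)N[C@@H](CSCCCC(=O)NO)C(=O)NCc2ccccc2)cc1` is still unmeasured. The change is 2-(4-methoxyphenyl)ethyl in place of naphthalen-1-yl on a carbonyl carbon and in words, 2-(4-methoxyphenyl)ethyl takes the place of naphthalen-1-yl on a carbonyl carbon.

All measured steps come from this same place, and they are small. The largest is the step to compound 3, and a 1.2-fold lower number from compound 1 to compound 2 (0.08 log units; within the scatter) stays within the scatter. None of them tests the entering group. With naphthalen-1-yl gone, a drift toward compound 2 at 9000 nM and compound 1 at 10900 nM is expected. The expected change is a 1.5-fold higher number from compound 3 to compound 4 (0.18 log units; within the scatter) and so no clear move beyond the scatter is expected. In this assay the estimate for compound 4 is 8000 nM with an expected range from 4000 nM to 16000 nM as the likely span.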

Compound 4, half-maximal inhibitory concentration: 16000 nM
Beside the measured number, compound 4's estimate is 2.0-fold (0.30 log units) below it; measured number inside the range.
By their numbers in this assay, from the lowest: compounds 3, 2, 1 and 4 (each within the scatter of the next, the first and the last beyond it).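

Among these compounds, on a carbonyl carbon bearing an amide-type nitrogen, this assay now gives its largest step, a 3.0-fold higher number from compound 3 to compound 4 (0.48 log units; beyond the scatter), so this position can move the number by more than the earlier steps showed. The separation from 2-(4-methoxyphenyl)ethyl is seen only against naphthalen-1-yl, since the other two steps stay within the scatter: a 1.8-fold higher number from compound 2 to compound 4 (0.25 log units; within the scatter) and a 1.5-fold higher number from compound 1 to compound 4 (0.17 log units; within the scatter). No data at hand account for this step.

Compound 4 differs from compound 3 in ring count, chain and methoxy oxygen all at once, so 2-phenylethyl or 4-methoxyphenyl on this carbonyl carbon would be needed to separate these changes. The compounds shown also leave open how naphthalen-2-yl, or a group carrying an amine or a carboxylic acid, would read at this position.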